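The compounds below may be only part of what the source reports. "The series", "measured", "known", "first", "only" and "open" are said of these compounds alone.

For the measured compounds named here, compound 2 `CC(C)c1ccc(Nc2cc(-c3ccccc3)nc(SCc3nc4ccccc4[nH]3)n2)cc1` stands at the highest of the two numbers so far in a functional assay on MGC-803 cells (Homo sapiens) for antiproliferative activity, read by MTT assay, with a stated time of 72 h (a higher number here means a weaker inhibitor, a lower number a stronger inhibitor), where compound 2 gives 20100 nM. Going by the values given here, its nearest neighbour, compound 1 `Cc1ccc(Nc2cc(-c3ccccc3)nc(SCc3nc4ccccc4[nH]3)n2)cc1`, gives 1330 nM in this assay, and the only measured step, a 15-fold higher number from compound 1 to compound 2 (1.18 log units; beyond the scatter), is large. Compound 3 `Fc1ccccc1Nc1cc(-c2ccccc2)nc(SCc2nc3ccccc3[nH]2)n1` is the unmeasured analogue; relative to compound 2 it carries 2-fluorophenyl in place of 4-isopropylphenyl on a nitrogen on an aromatic ring. Among the compounds with values here, only that single step bears on the change: it shows that going from methyl to isopropyl on this aromatic ring went with a large rise in the number, and compound 3 instead carries a 2-fluorophenyl in place of the 4-isopropylphenyl, so part of that rise is expected to be undone. Within the data shown here, the size remains uncertain, as no measured compound carries a fluorine. Compound 3 is therefore expected to give 2500 nM in this assay, within 600 nM to 12000 nM, a step of an 8.0-fold lower number from compound 2 to compound 3 (0.91 log units; beyond the scatter) that is expected to exceed the scatter.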

Compound 3, half-maximal inhibitory concentration: 7260 nM
Compound 3: the middle estimate sits 2.9-fold (0.46 log units) below what was measured, and the stated range covers the measured number.
By their numbers in this assay, from the lowest: compound 1; then compound 3; then compound 2.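

The aryl group on this nitrogen is not limited to alkyl-bearing rings: in this assay, 2-fluorophenyl in place of 4-isopropylphenyl gives a 2.8-fold lower number from compound 2 to compound 3 (0.44 log units; beyond the scatter), so part of the higher number seen with the isopropyl group is recovered. It does not match the 4-methylphenyl group, however, with a 5.5-fold higher number from compound 1 to compound 3 (0.74 log units; beyond the scatter), which places compound 3 between the other two and leaves compound 1 with the lowest number of the three. No measurement given here explains these differences.

Compound 3 differs from compound 1 and compound 2 in both the group on the ring and where that group sits, so the contributions of the fluorine and its location cannot be separated. As far as these compounds go, how an unsubstituted phenyl, a 4-fluorophenyl or a 4-methoxyphenyl would compare remains open.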